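The source may report more compounds than this note shows. Statements on the series, on what has been measured and on what is new or still open speak of the compounds shown alone.

In an assay on isolated protein for inhibition of A disintegrin and metalloproteinase with thrombospondin motifs 5 (Homo sapiens), read by spectrophotometry, with stated times of 10 min and 3 h (on this read-out higher numbers stand for weaker inhibition and lower numbers for stronger inhibition), compound 1 `O=C(NNC(=S)NCc1ccc(-c2ccccc2)cc1)c1ccc(Cl)cc1` gives 700 nM. Compound 3 `O=C(COc1ccc([N+](=O)[O-])cc1)NNC(=S)NCCCCC1CCCCC1` gives 810 nM in this assay. Compound 2 `O=C(COc1ccccc1)NNC(=S)NCCCCC1CCCCC1` reaches only the limit of this assay, > 100000 nM, so a bound and not a number is known for it, the case described by the limit of > 100000 nM in this assay, at which 1 of the 3 values shown sits. Within the data shown here, the single measured step, an at least 120-fold lower number from compound 2 to compound 3 (2.09 log units; beyond the scatter), concerns a nitro placed on the phenoxy ring; compound 4 `CC(=O)NNC(=S)NCCCCC1CCCCC1` removes that ring altogether, differing from compound 2 by hydrogen in place of phenoxy on a saturated chain carbon bound to a carbonyl carbon. Whether the loss of the ring helps is shown by no measured pair. Compound 2 stands at the limit, and the step from it is expected to be small, a number no higher from compound 2 to compound 4 (the limit leaves the size open). Compound 4 is expected to give 100000 nM, in a range from 20000 nM to 500000 nM, most likely again only as a limit.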

Compound 4, half-maximal inhibitory concentration: > 100000 nM
Compound 4 was reported as a limit (the forecaster's own chance of this, stated with the estimate: 70%); the middle value sits exactly at the limit.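

Compound 2 and compound 4 are both reported only as limits, and the step between them cannot be read. The compounds shown leave open whether hydrogen in place of phenoxy changes inhibition at all.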